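Working notes: adding hydroxy to the compound 3 benzyl ring

This account rests on a few compounds, and the source may have more. Where it says the series, first, only, none or still open, it means among the compounds named here.

- Compound 1 `COc1ccc(CN(C(=O)CSc2nc3ccccc3s2)c2cc(OC)c(OC)c(OC)c2)cc1C`: 34300 nM
- Compound 2 `COc1cc(N(Cc2ccc(C)cc2)C(=O)CSc2nc3ccccc3s2)cc(OC)c1OC`: > 80000 nM, a limit of the assay and not a number
- Compound 3 `COc1ccc(CN(C(=O)CSc2nc3ccccc3s2)c2cc(OC)c(OC)c(OC)c2)cc1`: 8460 nM

In a functional assay on PC-3 cells (Homo sapiens) for antiproliferative activity, read by MTT assay, with a stated time of 48 h (on this read-out lower numbers stand for stronger inhibition and higher numbers for weaker inhibition), compound 3 gives 8460 nM, the lowest of the two numbers in this series. The nearest is compound 1 at 34300 nM.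

Compound 4 `COc1ccc(CN(C(=O)CSc2nc3ccccc3s2)c2cc(OC)c(OC)c(OC)c2)cc1O` has hydroxy in place of hydrogen on an aromatic carbon, ortho to a methoxy group and meta to a large group: hydroxy in place of hydrogen on an aromatic carbon. This turns 4-methoxybenzyl into 3-hydroxy-4-methoxybenzyl.

The closest measured change is a 4.1-fold lower number from compound 1 to compound 3 (0.61 log units; beyond the scatter), which concerns methyl and hydrogen on the carbon that takes the hydroxy. Also relevant is an at least 9.4-fold lower number from compound 2 to compound 3 (0.97 log units; beyond the scatter), methoxy in place of methyl on another carbon of that ring. Both show that this ring responds to small changes, but neither tests hydroxy, so the direction is weakly held. A modest shift is expected, leaning to a lower number, and the estimated step is a 1.9-fold lower number from compound 3 to compound 4 (0.27 log units; within the scatter). For compound 4 the estimated value in this assay is 4500 nM, with an expected range of 900 nM to 22000 nM.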

Compound 4, half-maximal inhibitory concentration: 2110 nM
Beside the measured number, compound 4's estimate is 2.1-fold (0.33 log units) above it, within the range that was stated.
By their numbers in this assay, from the lowest: compound 4; then compound 3; then compound 1. At a limit, above all of these: compound 2.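

In this assay, among these compounds, hydroxy on the aromatic carbon ortho to a methoxy group gives a 4.0-fold lower number from compound 3 to compound 4 (0.60 log units; beyond the scatter), so this carbon accepts a group in place of hydrogen with a lower number, whereas methyl was the only group seen there before and gave a higher number than hydrogen. Hydroxy and methyl on that same carbon are set apart by a 16-fold lower number from compound 1 to compound 4 (1.21 log units; beyond the scatter), so the identity of the group there matters, not just the presence of one. Against the 4-methylphenyl of compound 2 the change reads an at least 37-fold lower number from compound 2 to compound 4 (1.57 log units; beyond the scatter), and that step rests on a limit of the assay, not a number: the limit of > 80000 nM in this assay, at which 1 of the 4 values shown sits.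

The compounds shown leave open whether an amine or a fluorine on this carbon would match hydroxy. Also open, as far as these compounds go, is whether hydroxy gives the same step when the neighbouring methoxy group is exchanged for an ethoxy group.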